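Trimming the side chain of a weak cytotoxic diarylmethane

The compounds below may be only part of what the source reports. "The series", "measured", "known", "first", "only" and "open" are said of these compounds alone.

Compound 1 `COC[C@@H](C)[C@H](C)C(c1ccc(O)c(OC)c1)c1ccc(O)c(OC)c1`: 73000 nM
Compound 2 `COc1ccc(C(c2ccc(OC)c(OC)c2)[C@H](C)[C@H](C)CO)cc1OC`: > 100000 nM

In a functional assay on HL-60 cells (Homo sapiens) for cytotoxicity, read by WST assay, with a stated time of 48 h (a higher number here means a weaker inhibitor, a lower number a stronger inhibitor), compound 1 gives 73000 nM. For compound 2 the result is a limit of the assay, > 100000 nM, not a number. Among the compounds with values here, compound 1 thus stands as the only compound with a number. The remaining value is the limit of > 100000 nM in this assay, at which 1 of the 2 values shown sits.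

Compound 3 `COc1cc(C(c2ccc(O)c(OC)c2)[C@H](C)C(C)C)ccc1O` is not yet measured. It differs from compound 1 in one place: 1,2-dimethylpropyl in place of 2-(methoxymethyl)-1-methylpropyl on a saturated chain carbon bound to two aromatic carbons. Within the data shown here, no measured pair shows how a change of this kind shifts the value, so the step of a 1.2-fold higher number from compound 1 to compound 3 (0.07 log units; within the scatter) is expected to stay within the usual scatter. Compound 3 is expected to give 85000 nM, between 35000 nM and 250000 nM.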

Compound 3, half-maximal inhibitory concentration: 17000 nM
The estimate for compound 3 lay 5.0-fold (0.70 log units) above the measured number; measured number outside the range, below it.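

On the saturated chain carbon bound to two aromatic carbons, the side chain clearly matters in this assay: 1,2-dimethylpropyl in place of 2-(methoxymethyl)-1-methylpropyl gives a 4.3-fold lower number from compound 1 to compound 3 (0.63 log units; beyond the scatter). The smaller chain without the oxygen is therefore the stronger of this pair, so the methoxymethyl part is not needed for this cytotoxicity. Nothing shown here explains why the value moves.

As far as these compounds go, whether removing the oxygen or shortening the chain drives the step stays open. So does how a longer alkyl chain, or a side chain carrying an amine, would behave on this carbon.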